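The source may report more compounds than this note shows. Statements on the series, on what has been measured and on what is new or still open speak of the compounds shown alone.

Measured compounds in a physicochemical assay for solubility; a lower number here means a less soluble compound, a higher number a more soluble compound:

- compound 1 `CC(C)(C)OC(=O)N1CCC[C@H]1C(=O)N1CCC(NS(=O)(=O)c2cc(S(=O)(=O)c3ccccc3)ccc2C(F)(F)F)CC1`: 25000 nM
- compound 2 `CC(C)(C)OC(=O)N1C(=O)CC[C@H]1C(=O)N1CCC(NS(=O)(=O)c2cc(S(=O)(=O)c3ccccc3)ccc2C(F)(F)F)CC1`: 50000 nM
- compound 3 `CC(C)C(=O)N1CCC[C@H]1C(=O)N1CCC(NS(=O)(=O)c2cc(S(=O)(=O)c3ccccc3)ccc2C(F)(F)F)CC1`: 100000 nM

Compound 3 gives the highest number of the three in this assay. Compound 2 sits within the scatter of it, so no order between compound 2 and compound 3 can be read from these numbers; compound 1 sits beyond the scatter, as the step of a 4.0-fold higher number from compound 1 to compound 3 (0.60 log units; beyond the scatter) shows, a modest rise on exchanging tert-butoxy for isopropyl on a carbonyl carbon.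

Compound 4 `CN(C)C(=O)N1CCC[C@H]1C(=O)N1CCC(NS(=O)(=O)c2cc(S(=O)(=O)c3ccccc3)ccc2C(F)(F)F)CC1` has not been measured. It differs from compound 3 by dimethylamino in place of isopropyl on a carbonyl carbon. Going by the values given here, the only step recorded at this carbonyl carbon is a 4.0-fold higher number from compound 1 to compound 3 (0.60 log units; beyond the scatter), which concerns a different pair of groups; no measured step pairs isopropyl against dimethylamino, so the direction is not settled by the data. With both groups of the same size and neither adding a donor or acceptor, a step within the scatter is the expectation, and compound 4 is estimated at 120000 nM, in the range 50000 nM to 300000 nM, which is expected to mean a step of a 1.2-fold higher number from compound 3 to compound 4 (0.08 log units; within the scatter).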

Compound 4, solubility: 100000 nM
Compound 4: the middle estimate sits 1.2-fold (0.08 log units) above what was measured; the range from low to high includes it.
By their numbers in this assay, from the lowest: compounds 1, 2, 3 and 4 (each within the scatter of the next, the first and the last beyond it).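

In this assay, dimethylamino in place of isopropyl on this carbonyl carbon gives no change at the digits printed from compound 3 to compound 4 (within the scatter), so a carbon-only group and a nitrogen-containing group with the same heavy-atom count are not separated at this position. Replacing tert-butoxy with dimethylamino gives a 4.0-fold higher number from compound 1 to compound 4 (0.60 log units; beyond the scatter), matching a 4.0-fold higher number from compound 1 to compound 3 (0.60 log units; beyond the scatter), so the rise on leaving tert-butoxy is now seen with two replacing groups rather than one. No supporting data bear on the cause of these steps.

Still open, going by these compounds, is whether a carboxylic acid, a primary amine or a longer chain on this carbonyl carbon would stand apart from compound 3 and compound 4. Also open, on these data alone, is whether the exchange of isopropyl for dimethylamino reads the same on the core of compound 2.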